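Chain extension on the inactive compound 3

A few compounds are considered here, and "the series" means these few. Any claim that something is new, unique, unknown or untested is made for them only; others in the source may bear on it.

Values so far in a functional assay on HL-60 cells (Homo sapiens) for inhibition, read by MTT assay, with a stated time of 72 h (a higher number here means a weaker inhibitor, a lower number a stronger inhibitor), are these.
compound 1 `Cc1nc(-c2ccc(F)cc2)c(C(=O)N2CCN(c3cccc(Cl)c3)CC2)o1` gives 40.1 nM
compound 2 `CC(=O)Nc1cccc(-c2nc(C)oc2C(=O)N2CCN(c3cccc(Cl)c3)CC2)c1` gives 208 nM
compound 3 `COc1ccc(-c2nc(C)oc2C(=O)N2CCN(c3cccc(Cl)c3)CC2)cc1` gives "not active" (no number reported)

Compound 3 has no single number in this assay and is reported only as "not active" (no number reported) here, so it offers no numerical starting point. Compound 4 `CCCc1nc(-c2ccc(OC)cc2)c(C(=O)N2CCN(c3cccc(Cl)c3)CC2)o1` differs from compound 3 by one change ethyl in place of hydrogen on a saturated chain carbon bound to an aromatic carbon in which ethyl takes the place of hydrogen on a saturated chain carbon bound to an aromatic carbon. Cut one bond further out, this reads as methyl to propyl.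

Among the measured compounds shown here, only one measured step is available, a 5.2-fold higher number from compound 1 to compound 2 (0.71 log units; beyond the scatter) and it is a modest one. It replaces 4-fluorophenyl with 3-acetamidophenyl on an aromatic carbon, so it is a different change at a different place and gives no direct measure for this one. For the measured compounds named here, no measured step covers a change of chain, and no size of step can be stated from compound 3. The expectation is therefore only loose: any number for compound 4 should lie on the weak side of compound 2 at 208 nM in this series, and a second report without a number remains quite possible.

Compound 4 is estimated at 800 nM with an expected range from 80 nM to 8000 nM in this assay for now.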

Compound 4, half-maximal inhibitory concentration: "not active" (no number reported)
Compound 4 has no reported number here, and the estimate cannot be compared.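

In this assay compound 3 and compound 4 are both reported only as "not active", without a number, so no step can be read between them. Nothing available bears on this result. The compounds shown leave open whether methyl to propyl alters activity at all, and how either compound stands numerically against compound 1 or compound 2.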